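Compound 3 to compound 4: a side-chain swap at the limit

The compounds below may be only part of what the source reports. "The series", "measured", "known", "first", "only" and "open" are said of these compounds alone.

In a physicochemical assay for solubility, in phosphate buffer, measured as thermodynamic solubility, at pH 2 (a lower number here means a less soluble compound, a higher number a more soluble compound), compound 1 `CCC(CC)N1CCN(c2nc3c(c(Nc4ccc(C(F)(F)F)cc4)n2)CCN(c2ncccc2C(F)(F)F)CC3)CC1` gives 243 ug/mL and compound 2 `CC(C)(C)OC(=O)N1CCCC(Nc2nc3c(c(Nc4ccc(C(F)(F)F)cc4)n2)CCN(c2ncccc2C(F)(F)F)CC3)C1` gives 1 ug/mL. Compound 3 `CN(c1nc2c(c(Nc3ccc(C(F)(F)F)cc3)n1)CCN(c1ncccc1C(F)(F)F)CC2)C1CCCNC1` gives > 241 ug/mL, which is a limit and not a number, so its position is known only as that limit.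

Compound 4 `CN1CCCCC1CNc1nc2c(c(Nc3ccc(C(F)(F)F)cc3)n1)CCN(c1ncccc1C(F)(F)F)CC2` replaces methyl(piperidin-3-yl)amino with ((1-methylpiperidin-2-yl)methyl)amino on an aromatic carbon (((1-methylpiperidin-2-yl)methyl)amino in place of methyl(piperidin-3-yl)amino on an aromatic carbon). One six-membered non-aromatic ring with 1 hetero atom leaves and one enters.

Among the compounds with values here, the only measured step bearing on this change is a step that the limit leaves unreadable from compound 1 to compound 3, so it offers no size to carry over. Within the data shown here, the expectation therefore rests on the values alone, with compound 1 at 243 ug/mL as the one high readable value. Compound 2 at 1 ug/mL shows that this series can also fall far lower, so the range is wide on the low side.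

No step beyond the scatter is expected in this assay, and the estimated change is an at least 1.0-fold lower number from compound 3 to compound 4 (0.03 log units; that floor lies within the scatter). Compound 4 is expected at 220 ug/mL, with an estimated range of 90 ug/mL to 280 ug/mL.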

Compound 4, solubility: > 277 ug/mL
Compound 4 ended at the assay's limit; the forecaster's own chance of this, stated with the estimate: 55%; middle value at least 1.2-fold (0.10 log units) away from the limit.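

Compound 4 gives > 277 ug/mL in this assay, which is a limit of the assay and not a number. With ((1-methylpiperidin-2-yl)methyl)amino on this aromatic carbon, between two ring nitrogen atoms, the value stays at a limit as it did with methyl(piperidin-3-yl)amino, so the step between compound 3 and compound 4 cannot be read. Against the one readable high value in this group, the record is an at least 1.1-fold higher number from compound 1 to compound 4 (0.05 log units; that floor lies within the scatter).

As far as these compounds go, the actual values of compound 3 and compound 4 remain unknown, which leaves the order of these two side chains open. Also open, from the compounds shown here alone, is whether a morpholin-4-yl group or a side chain ending in a carboxylic acid at this position would reach a limit in this assay.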